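Series notes: methyl on the chain carbon, cytotoxicity

The source may report more compounds than this note shows. Statements on the series, on what has been measured and on what is new or still open speak of the compounds shown alone.

Measured so far:
compound 1, `CC(c1nccs1)C(C#N)C#N`: > 120000 nM
compound 2, `N#CC(C#N)Cc1nccs1`: > 120000 nM

In a functional assay on MCF7 cells (Homo sapiens) for cytotoxicity, read by MTT assay, with a stated time of 48 h (a lower number here means a stronger inhibitor, a higher number a weaker inhibitor), compound 1 gives > 120000 nM, which is a limit of the assay and not a number. Compound 2 gives > 120000 nM, likewise a limit. The step that the two limits leave unreadable from compound 1 to compound 2 is not readable because both values sit at the limit of > 120000 nM in this assay, at which 2 of the 2 values shown sit. Compound 1 therefore stands only at a limit, with nothing measured below it.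

The next compound, compound 3 `CC(C)(c1nccs1)C(C#N)C#N`, differs from compound 1 by methyl in place of hydrogen on a saturated chain carbon bound to an aromatic carbon and two saturated chain carbons. Among the compounds with values here, the only measured step that bears on it is the one from compound 1 to compound 2, and that one gives no readable size. There is thus no basis for expecting a shift beyond the scatter in this assay; the expected step is a step that the limit leaves unreadable from compound 1 to compound 3. Compound 3 is expected to give about 200000 nM, within 120000 nM to 1000000 nM, most probably reported again as a limit.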

Compound 3, half-maximal inhibitory concentration: > 120000 nM
Compound 3: only a limit was reported (the forecaster's own chance of this, stated with the estimate: 90%); the middle value lies beyond the limit too.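

For compound 3 the result is > 120000 nM and this is a limit of the assay, not a number. No new step can be read between compound 1 and compound 3. The compounds shown leave open what size, if any, the effect of methyl in place of hydrogen on the chain carbon has on cytotoxicity.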